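Phenethyl in Place of 2-Fluorophenyl: Expected Cytotoxicity

The source may hold more compounds than are shown below. What is called first, only, known or untested is meant among the compounds shown, and "the series" means these compounds.

Compound 1 `Fc1ccccc1Cn1ccc2nc(-c3ccccc3)nc-2c1`: > 100000 nM in an ADME assay on MDBK cells (Bos taurus) for cytotoxicity (on this read-out lower numbers stand for higher toxicity in this test and higher numbers for lower toxicity in this test), a limit.
Compound 2 `FC(F)(F)c1ccccc1Cn1ccc2nc(-c3ccccc3)nc-2c1`: > 100000 nM in this assay, a limit.
Compound 3 `c1ccc(-c2ccc(Cn3ccc4nc(-c5ccccc5)nc-4c3)cc2)cc1`: 18000 nM in this assay.

Compound 1 therefore stands at the limit of > 100000 nM in this assay, at which 2 of the 3 values shown sit, and has no number of its own. Among the compounds with values here, the single measured step, a step that the two limits leave unreadable from compound 1 to compound 2, cannot be read. Compound 4 `c1ccc(CCCn2ccc3nc(-c4ccccc4)nc-3c2)cc1` differs from compound 1 by phenethyl in place of 2-fluorophenyl on a saturated chain carbon bound to an aromatic nitrogen. Within the data shown here, no measured step bears on that exchange, so the expectation rests on the position of compound 1 alone. Compound 4 is expected to stay weakly toxic in this assay, with an estimate of 80000 nM and a range from 20000 nM to 300000 nM. The expected step of an at least 1.2-fold lower number from compound 1 to compound 4 (0.09 log units; that floor lies within the scatter) is accordingly taken to lie within the scatter, with a fair chance that only a limit is reported again.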

Compound 4, half-maximal cytotoxic concentration: > 100000 nM
Compound 4 ended at the assay's limit (the forecaster's own chance of this, stated with the estimate: 55%); at least 1.2-fold (0.09 log units) between middle value and limit.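

In this assay compound 1 and compound 4 each stand at a limit, not a number, so the step between them cannot be read: the limit of > 100000 nM in this assay, at which 3 of the 4 values shown sit. The compounds shown leave open whether phenethyl in place of 2-fluorophenyl changes the cytotoxic concentration at all.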